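Swapping the ether substituent on a shared oxazolone core

A few compounds are considered here, and "the series" means these few. Any claim that something is new, unique, unknown or untested is made for them only; others in the source may bear on it.

Of the compounds shown here, three built on one core have been measured. Compound 1 `CCc1cc2oc(=O)n(CCC(=O)O)c2cc1Cl` gives 316 nM in an assay on HEK293 cells for inhibition of kynurenine 3-monooxygenase (Homo sapiens), read by LC-MS, with a stated time of 20 h; a higher number here means a weaker inhibitor, a lower number a stronger inhibitor. Compound 2 `O=C(O)CCn1c(=O)oc2cc(OCC3CC3)c(Cl)cc21` gives 1580 nM in this assay, and compound 3 `O=C(O)CCn1c(=O)oc2cc(Cl)c(Cl)cc21` gives 2000 nM. Compound 2 therefore holds the second highest of the three numbers: its nearest neighbour is compound 3, with a 1.3-fold higher number from compound 2 to compound 3 (0.10 log units; within the scatter), while the furthest is compound 1, with a 5.0-fold higher number from compound 1 to compound 2 (0.70 log units; beyond the scatter).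

Compound 4 `C[C@@H](Oc1cc2oc(=O)n(CCC(=O)O)c2cc1Cl)c1ncccn1` differs from compound 2 by a group of 8 heavy atoms (6 carbon, 2 nitrogen; one six-membered aromatic ring with 2 hetero atoms) in place of a group of 4 heavy atoms (4 carbon; one three-membered non-aromatic ring of carbon only), on an oxygen on an aromatic ring. The measured steps all concern the group on the aromatic carbon itself rather than a group on an oxygen: a 5.0-fold higher number from compound 1 to compound 2 (0.70 log units; beyond the scatter) and a 6.3-fold higher number from compound 1 to compound 3 (0.80 log units; beyond the scatter) were modest, and a 1.3-fold higher number from compound 2 to compound 3 (0.10 log units; within the scatter) stayed within the scatter. Going by the values given here, no step varies what sits on the oxygen, so there is no direct precedent for the change to compound 4. Because cyclopropylmethoxy and chloro on that carbon gave a 1.3-fold higher number from compound 2 to compound 3 (0.10 log units; within the scatter), the author expects the new substituent to leave the number in a similar region, with a step of a 1.1-fold lower number from compound 2 to compound 4 (0.05 log units; within the scatter) that may not exceed the scatter. Compound 4 is estimated at 1400 nM, within a range from 450 nM to 4500 nM.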

Compound 4, half-maximal inhibitory concentration: 3160 nM
Compound 4: middle estimate off by 2.3-fold (0.35 log units), on the low side; low and high end bracket the measured number.
By their numbers in this assay, from the lowest: compound 1; then compounds 2, 3 and 4 (each within the scatter of the next).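

On the oxygen on an aromatic ring, the group with a six-membered aromatic ring with 2 hetero atoms and 1 defined stereocentre in place of cyclopropylmethyl gives, in this assay, a 2.0-fold higher number from compound 2 to compound 4 (0.30 log units; within the scatter), and this is the only step shown that varies what sits on that oxygen. It shows that a group of 8 heavy atoms, carrying 2 hydrogen-bond acceptors, can stand there in place of a group of 4 heavy atoms with no step beyond the scatter, so compound 4 joins compound 2 and compound 3 in the same region of numbers. No measurement shown here accounts for this step.

The compounds shown leave open whether the aromatic ring on the oxygen matters through its nitrogens, which a plain phenyl ring or a simple benzyl group in its place would test, and whether a longer chain or an amine on that oxygen would give a step beyond the scatter. They also leave open what the defined stereocentre contributes, since the opposite configuration and the form without its methyl group do not stand among them.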